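The source may hold more compounds than are shown below. What is called first, only, known or untested is meant among the compounds shown, and "the series" means these compounds.

Compounds measured in a functional assay on isolated protein for inhibition of Glucose-dependent insulinotropic receptor (Rattus norvegicus), read by HTRF and cAMP accumulation; on this read-out lower numbers stand for smaller maximal responses and higher numbers for larger maximal responses:
- compound 1 `Cc1nc(S(C)(=O)=O)ccc1Oc1ncnc(OC2CCN(C(=O)O[C@@H](C)C(F)(F)F)CC2)c1F`, with 80%
- compound 2 `Cc1nc(S(C)(=O)=O)ccc1Oc1ncnc(OC2CCN(C(=O)SC(C)C)CC2)c1F`, with 81%
- compound 3 `Cc1nc(S(C)(=O)=O)ccc1Oc1ncnc(OC2CCN(C(=O)C(F)(F)F)CC2)c1F`, with 76%

Compound 1 stands second highest of these three numbers. Its nearest neighbour is compound 2, at a number 1 percentage points higher from compound 1 to compound 2 (within the scatter); its furthest is compound 3, at a number 4 percentage points lower from compound 1 to compound 3 (within the scatter). Compound 4 `CCc1cnc(C(=O)N2CCC(Oc3ncnc(Oc4ccc(S(C)(=O)=O)nc4C)c3F)CC2)nc1` is still to be measured. It differs from compound 1 in one place: 5-ethylpyrimidin-2-yl in place of 1-(trifluoromethyl)ethoxy on a carbonyl carbon.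

Every measured step also replaces the group on this carbonyl carbon: a number 1 percentage points higher from compound 1 to compound 2 (within the scatter), a number 4 percentage points lower from compound 1 to compound 3 (within the scatter) and a number 5 percentage points lower from compound 2 to compound 3 (within the scatter), each within the scatter. For the measured compounds named here, on that basis no step beyond the scatter is expected in this assay for compound 4, although the group entering here is an aromatic ring, which none of the measured steps covers. Compound 4 is therefore estimated at 78%, between 62% and 92%, an expected step of a number 2 percentage points lower from compound 1 to compound 4 (within the scatter).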

Compound 4, largest response reached (reported as efficacy), in percent of the reference or control that the assay uses: 80%
Beside the measured number, compound 4's estimate is 2 percentage points below it, within the range that was stated.
By their numbers in this assay, from the lowest: compounds 3, 1, 4 and 2 (each within the scatter of the next).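

With an aromatic ring on the carbonyl carbon, this assay gives no change at the digits printed from compound 1 to compound 4 (within the scatter) and a number 4 percentage points higher from compound 3 to compound 4 (within the scatter) and also a number 1 percentage points lower from compound 2 to compound 4 (within the scatter) for 5-ethylpyrimidin-2-yl. The maximal response at this position therefore stays within the scatter even when a six-membered aromatic ring with 2 hetero atoms enters and the defined stereocentre leaves. No evidence is available that bears on this result. Still open, as far as these compounds go, is whether a phenyl ring or a dimethylamino group on this carbonyl carbon would also stay within the scatter.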